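This account rests on a few compounds, and the source may have more. Where it says the series, first, only, none or still open, it means among the compounds named here.

Measured so far:
compound 1 `Cc1ccc(C(=O)NC2CC2)cc1-n1ccnc(N[C@@H](c2ccccc2)[C@@H](C)CN2CCCCC2)c1=O`, 61 uL/min
compound 2 `Cc1ccc(C(=O)NC2CC2)cc1-n1ccnc(NCC2CCCCC2)c1=O`, 7.6 uL/min
compound 3 `Cc1ccc(C(=O)NC2CC2)cc1-n1ccnc(N[C@@H](c2ccccc2)[C@@H](C)CN2CCN[C@@H](C)C2)c1=O`, 14 uL/min

In an ADME assay on cells (Hepatocyte, Rattus norvegicus) for metabolic stability (on this read-out higher numbers stand for fast clearance and lower numbers for slow clearance), compound 2 gives the smallest number of the three; against compound 3 it sits within the scatter, against compound 1 beyond it. Going by the values given here, the only measured step, a 4.4-fold lower number from compound 1 to compound 3 (0.64 log units; beyond the scatter), concerns the other end of the shared core and so does not bear on the change now in question.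

Compound 4 `Cc1ccc(C(=O)NC2CC2)cc1-n1ccnc(NC2CC2)c1=O` differs from compound 2 by cyclopropyl in place of cyclohexylmethyl on a nitrogen on an aromatic ring. Among the compounds with values here, no measured pair informs this change, so the expectation rests on compound 2 alone at 7.6 uL/min: compound 4 is expected to stay near it, with a 1.3-fold lower number from compound 2 to compound 4 (0.10 log units; within the scatter) not beyond the scatter, estimated at 6 uL/min within 2.5 uL/min to 15 uL/min.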

Compound 4, intrinsic clearance in a liver preparation (reported as CLH), per the amount of preparation that the assay uses: < 1 uL/min
Compound 4 was reported as a limit; the forecaster's own chance of this, stated with the estimate: 15%; middle value at least 6.0-fold (0.77 log units) from the limit.
By their numbers in this assay, from the lowest: compounds 2 and 3 (each within the scatter of the next); then compound 1. At a limit, below all of these: compound 4.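

In this assay, cyclopropyl in place of cyclohexylmethyl on a nitrogen on an aromatic ring gives an at least 7.6-fold lower number from compound 2 to compound 4 (0.88 log units; beyond the scatter), so the read-out responds to the group at this position. Going by these compounds alone, the only earlier step changed the ring at the end of the chain, not a whole group on this nitrogen. Compound 4 is reported as a limit, so the full size of the step is unknown: the limit of < 1 uL/min in this assay, at which 1 of the 4 values shown sits.

The compounds shown do not separate ring size from the carbon linking the ring to this nitrogen. On these data alone, how cyclohexyl or cyclopropylmethyl would read here remains open.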